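Working notes on compound 4 derived from compound 1

A few compounds are considered here, and "the series" means these few. Any claim that something is new, unique, unknown or untested is made for them only; others in the source may bear on it.

Three measured compounds share one core. Compound 1 `O=S(=O)(NCCCNCc1ccc(Cl)cc1)c1cc(C(F)(F)F)cc(C(F)(F)F)c1`, compound 2 `O=S(=O)(NCCNCc1ccc(-c2ccccc2)cc1)c1cc(C(F)(F)F)cc(C(F)(F)F)c1` and compound 3 `O=S(=O)(NCCCNCc1ccc(-c2ccccc2)cc1)c1cc(C(F)(F)F)cc(C(F)(F)F)c1` have each been tested in a functional assay on HT-29 cells (Homo sapiens) for inhibition, read by MTT assay, with a stated time of 72 h; a higher number here means a weaker inhibitor of growth, a lower number a stronger inhibitor of growth. Compound 1 gives 2800 nM, compound 2 gives 2700 nM and compound 3 gives 2300 nM. Compound 1 stands with the highest of the three numbers, but its nearest neighbour compound 2 and its furthest neighbour compound 3 both fall within the scatter of it, so the three cannot be separated. Among the measured compounds shown here, the single step that differs in one place, a 1.2-fold lower number from compound 1 to compound 3 (0.09 log units; within the scatter), shows that exchanging the group on that aromatic carbon left the number where it was.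

Compound 4 `O=S(=O)(NCCCNCc1ccc(Cl)c(C(F)(F)F)c1)c1cc(C(F)(F)F)cc(C(F)(F)F)c1` is not yet measured. It differs from compound 1 in one place: trifluoromethyl in place of hydrogen on an aromatic carbon. For the measured compounds named here, no measured step adds a group to a ring that already carries one; the only step available, a 1.2-fold lower number from compound 1 to compound 3 (0.09 log units; within the scatter), replaced a group in that region and stayed within the scatter, and nothing shows this part of the molecule to move the number. The step of a 1.1-fold lower number from compound 1 to compound 4 (0.05 log units; within the scatter) is therefore expected to be small and without a sure direction. Compound 4 is estimated at 2500 nM, with an expected range from 1200 nM to 5500 nM.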

Compound 4, concentration for 50% growth inhibition: 11000 nM
For compound 4 the middle estimate is 4.4-fold (0.64 log units) below the measured one; measured number above the stated range.
By their numbers in this assay, from the lowest: compounds 3, 2 and 1 (each within the scatter of the next); then compound 4.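

In this assay the ring carrying the chloro group is no longer silent: trifluoromethyl in place of hydrogen, ortho to that chloro group and meta to a large group, gives a 3.9-fold higher number from compound 1 to compound 4 (0.59 log units; beyond the scatter) and is the only step shown that lies beyond the scatter. The step of a 1.2-fold lower number from compound 1 to compound 3 (0.09 log units; within the scatter) exchanged the chloro group itself and left the number within the scatter, whereas this change keeps the chloro group, adds 4 heavy atoms on a carbon that carried only hydrogen, and moves the number toward weaker inhibition of growth. Nothing available accounts for this step.

On these data alone, it remains open whether the loss belongs to trifluoromethyl itself or would also follow from a fluoro, methyl or methoxy group on the same aromatic carbon, and whether the same group placed elsewhere on this ring would behave alike. As far as these compounds go, it is also open whether the step would carry over to the biphenyl-type phenyl substituent of compound 3 or to the shorter chain of compound 2.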